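This account rests on a few compounds, and the source may have more. Where it says the series, first, only, none or still open, it means among the compounds named here.

Measured compounds:
compound 1, `Oc1ccc(C(c2c[nH]c3ccc(Br)cc23)c2c[nH]c3ccc(Br)cc23)cc1`: 3500 nM
compound 2, `COc1cccc(C(c2c[nH]c3ccc(Br)cc23)c2c[nH]c3ccc(Br)cc23)c1OC`: 89000 nM

Both numbers come from a functional assay on MCF7 cells (Homo sapiens) for inhibition, read by MTT assay, with a stated time of 48 h; on this read-out lower numbers stand for stronger inhibition and higher numbers for weaker inhibition. Among the compounds with values here, compound 1 stands at the lower of the two numbers, and its only measured neighbour, compound 2, shows a 25-fold higher number from compound 1 to compound 2 (1.41 log units; beyond the scatter).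

Compound 3, `COc1ccc(C(c2c[nH]c3ccc(Br)cc23)c2c[nH]c3ccc(Br)cc23)c(OC)c1`, is not yet measured in this assay. It differs from compound 1 as follows: 2,4-dimethoxyphenyl in place of 4-hydroxyphenyl on a saturated chain carbon bound to two aromatic carbons

Within the data shown here, one measured step bears on this change. From compound 1 to compound 2 the same 4-hydroxyphenyl was replaced by a dimethoxyphenyl on the same saturated chain carbon bound to two aromatic carbons, and that step was large, a 25-fold higher number from compound 1 to compound 2 (1.41 log units; beyond the scatter). Compound 3 carries the two methoxy groups in a different arrangement, so the step need not be as large, but the loss of the 4-hydroxyphenyl is shared, and a higher number beyond the scatter is expected. Compound 3 is therefore estimated at 35000 nM, with a range from 8000 nM to 150000 nM, a step of a 10-fold higher number from compound 1 to compound 3 (1.00 log units; beyond the scatter) expected from compound 1.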

Compound 3, half-maximal inhibitory concentration: 77500 nM
The estimate for compound 3 lay 2.2-fold (0.35 log units) below the measured number, and the stated range covers the measured number.
By their numbers in this assay, from the lowest: compound 1; then compounds 3 and 2 (each within the scatter of the next).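

In this assay the second dimethoxyphenyl group also stands far from the 4-hydroxyphenyl group, with a 22-fold higher number from compound 1 to compound 3 (1.35 log units; beyond the scatter) and little separating the two arrangements, as a 1.1-fold lower number from compound 2 to compound 3 (0.06 log units; within the scatter) shows. On this saturated chain carbon bound to two aromatic carbons, the large step away from 4-hydroxyphenyl therefore holds for both 2,3-dimethoxyphenyl and 2,4-dimethoxyphenyl, and these two arrangements of the methoxy groups do not tell the compounds apart. No measured evidence accounts for this result.

The compounds shown do not separate the loss of the hydroxyl group from the arrival of two methoxy groups, so it stays open which of these changes matters. Also open, on these data alone, is how a 4-methoxyphenyl or a 4-aminophenyl group would stand on this carbon.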